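Bromo in place of chloro: what compound 4 should show

A few compounds are considered here, and "the series" means these few. Any claim that something is new, unique, unknown or untested is made for them only; others in the source may bear on it.

In a functional assay on B16 cells (Mus musculus) for antiproliferative activity, read by MTT assay, with a stated time of 24 h (on this read-out lower numbers stand for stronger inhibition and higher numbers for weaker inhibition), compound 1 `COc1cccc(C(=O)Oc2ccc3c(=O)c(-c4cc(OC)c(OC)cc4OC)coc3c2)c1` gives > 10000 nM, which is a limit of the assay and not a number. Compound 2 `COc1cc(OC)c(-c2coc3cc(OCc4ccccc4F)ccc3c2=O)cc1OC` gives 1610 nM and compound 3 `COc1cc(OC)c(-c2coc3cc(OCc4cccc(Cl)c4)ccc3c2=O)cc1OC` gives 2280 nM, two numbers within the scatter of each other. Compound 4 `COc1cc(OC)c(-c2coc3cc(OCc4cccc(Br)c4)ccc3c2=O)cc1OC` carries bromo in place of chloro on an aromatic carbon. The closest measured change is a 1.4-fold higher number from compound 2 to compound 3 (0.15 log units; within the scatter), also within the scatter. The larger at least 6.2-fold lower number from compound 1 to compound 2 (0.79 log units; beyond the scatter) and an at least 4.3-fold lower number from compound 1 to compound 3 (0.64 log units; beyond the scatter) replace a different group, so they bear on this change only weakly. The expected change is a 1.1-fold lower number from compound 3 to compound 4 (0.04 log units; within the scatter), with no shift beyond the scatter. Compound 4 is estimated at 2100 nM, with an expected range of 1000 nM to 4500 nM.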

Compound 4, half-maximal inhibitory concentration: 4400 nM
The estimate for compound 4 lay 2.1-fold (0.32 log units) below the measured number; the range from low to high includes it.
By their numbers in this assay, from the lowest: compounds 2, 3 and 4 (each within the scatter of the next, the first and the last beyond it). At a limit, above all of these: compound 1.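

On this aromatic carbon, bromo in place of chloro gives a 1.9-fold higher number from compound 3 to compound 4 (0.29 log units; within the scatter), so this exchange alone does not separate the two compounds. Unlike 3-chlorobenzyl, however, 3-bromobenzyl does separate from 2-fluorobenzyl, with a 2.7-fold higher number from compound 2 to compound 4 (0.44 log units; beyond the scatter). The step of an at least 2.2-fold lower number from compound 1 to compound 4 (0.35 log units; beyond the scatter) also lies beyond the scatter, but compound 1 stands at a limit, so this step is only a bound: the limit of > 10000 nM in this assay, at which 1 of the 4 values shown sits.

As far as these compounds go, whether iodo or an amine on this aromatic carbon would stay within the scatter of compound 3 remains open. The halogen and its place also remain unseparated, since 2-fluorobenzyl differs from the other two groups in both.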